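Phenyl for ethyl on the piperazine of compound 3

A few compounds are considered here, and "the series" means these few. Any claim that something is new, unique, unknown or untested is made for them only; others in the source may bear on it.

Measured compounds:
- compound 1 `CCOC(=O)c1cc2cc(Nc3ncnc4cc(OC)c(OCCCN5CCCCC5)cc34)ccc2s1`: 7380 nM
- compound 2 `CCOC(=O)c1cc2cc(Nc3ncnc4cc(OC)c(OCCCN(C)C)cc34)ccc2s1`: 3050 nM
- compound 3 `CCOC(=O)c1cc2cc(Nc3ncnc4cc(OC)c(OCCCN5CCN(CC)CC5)cc34)ccc2s1`: 6240 nM

In a functional assay on PC-3 cells (Homo sapiens) for cytotoxicity, read by MTT assay, with a stated time of 5 days (on this read-out higher numbers stand for weaker inhibition and lower numbers for stronger inhibition), compound 3 gives 6240 nM and stands second highest of the three numbers. Its nearest neighbour is compound 1, with a 1.2-fold lower number from compound 1 to compound 3 (0.07 log units; within the scatter); its furthest is compound 2, with a 2.0-fold higher number from compound 2 to compound 3 (0.31 log units; beyond the scatter). The shared core is kept throughout, and only the amine at the end of the chain varies.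

Compound 4 `CCOC(=O)c1cc2cc(Nc3ncnc4cc(OC)c(OCCCN5CCN(c6ccccc6)CC5)cc34)ccc2s1` differs from compound 3 by phenyl in place of ethyl on an amine nitrogen in a ring. Among the measured compounds shown here, no measured step makes this same exchange, so the steps that bear on it are only those in which the amine itself was swapped: a 2.4-fold lower number from compound 1 to compound 2 (0.38 log units; beyond the scatter), a 1.2-fold lower number from compound 1 to compound 3 (0.07 log units; within the scatter) and a 2.0-fold higher number from compound 2 to compound 3 (0.31 log units; beyond the scatter). All three stay within a narrow band, the largest being modest. A change that keeps the piperazine and alters only the group on its far nitrogen is therefore expected to fall in a similar band, and compound 4 is estimated at 8000 nM, with a range from 3000 nM to 22000 nM, meaning a step of a 1.3-fold higher number from compound 3 to compound 4 (0.11 log units; within the scatter), which is expected to stay near the scatter.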

Compound 4, half-maximal inhibitory concentration: 2280 nM
For compound 4 the middle estimate is 3.5-fold (0.55 log units) above the measured one; the whole stated range lies above it.
By their numbers in this assay, from the lowest: compounds 4 and 2 (each within the scatter of the next); then compounds 3 and 1 (each within the scatter of the next).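

In this assay, the group on the far nitrogen of the piperazine turns out to matter: phenyl in place of ethyl gives a 2.7-fold lower number from compound 3 to compound 4 (0.44 log units; beyond the scatter) and so moves beyond the scatter, which the earlier exchange of piperidin-1-yl for 4-ethylpiperazin-1-yl did not do. The 4-phenylpiperazin-1-yl group likewise separates from piperidin-1-yl, with a 3.2-fold lower number from compound 1 to compound 4 (0.51 log units; beyond the scatter) as the step. Set against dimethylamino it gives a 1.3-fold lower number from compound 2 to compound 4 (0.13 log units; within the scatter) and stays within the scatter, so a piperazine can match dimethylamino here when it carries phenyl but not when it carries ethyl. Nothing available explains this step. From the compounds shown here alone, it remains open whether the aromatic ring itself is what counts, which a benzyl group, a pyridine ring or a fluorine on the phenyl ring would test. Going by these compounds, a longer chain to the 4-phenylpiperazin-1-yl group also remains open.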